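This account rests on a few compounds, and the source may have more. Where it says the series, first, only, none or still open, it means among the compounds named here.

Measured so far in a functional assay on the whole organism (strain Sprague-Dawley) for inhibition, with Rattus norvegicus as the target, read by paw edema, with stated times of 1 h and 3 h, at a dose of 50 mg/kg by the oral route; on this read-out higher numbers stand for more inhibition at the one dose given (going by the name of the read-out) and lower numbers for less inhibition:
- compound 1 `CN(C)c1nc(N)sc1C(=O)c1cnc2ccccn12` — 32%
- compound 2 `Cc1ccc2ncc(C(=O)c3sc(N)nc3N(C)C)n2c1` — 23%
- compound 3 `Nc1ncc(C(=O)c2cnc3ccccn23)s1` — 33%

Compound 3 stands at the top of the three numbers, but its gaps to compound 1 and to compound 2 are both within the scatter, so no order among the three is claimed.

Two changes have been made on this core. The first is methyl in place of hydrogen on an aromatic carbon, which gave a number 9 percentage points lower from compound 1 to compound 2 (within the scatter). The second is hydrogen in place of dimethylamino on an aromatic carbon, which gave a number 1 percentage points higher from compound 1 to compound 3 (within the scatter); this is also the difference between the core of compound 1 and the core of compound 3.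

Compound 4 `Cc1cccn2c(C(=O)c3cnc(N)s3)cnc12` is not yet measured. It differs from compound 3 by methyl in place of hydrogen on an aromatic carbon. Going by the values given here, this is the same kind of change as the one from compound 1 to compound 2: methyl in place of hydrogen on an aromatic carbon of the six-membered aromatic ring with one nitrogen, two atoms from the ring nitrogen and meta to a fused ring in both cases. The places are not identical: in compound 4 the methyl is also ortho to a fused ring, whereas in compound 2 it is para to a fused ring.

Among the compounds with values here, only one earlier example of this kind of change exists, and it lay within the scatter. The expectation for compound 4 therefore rests on compound 3 at 33% and on the earlier step of a number 9 percentage points lower from compound 1 to compound 2 (within the scatter), and the step is estimated as a number 6 percentage points lower from compound 3 to compound 4 (within the scatter). Within the data shown here, compound 4 is expected to give about 27%, with a range from 12% to 42%, since the single precedent does not separate from the scatter.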

Compound 4, a percentage reported as inhibition, in the whole organism at one dose (the size of the read-out at that dose, not a potency): 31%
The estimate for compound 4 lay 4 percentage points below the measured number; the measured number falls inside the stated range.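

In this assay methyl in place of hydrogen on an aromatic carbon gives a number 2 percentage points lower from compound 3 to compound 4 (within the scatter) and so does not separate from the scatter on this second core. This does not show that the methyl leaves the read-out untouched, nor that the change carries a fixed size from one core to another, and the two places are not identical, since the methyl of compound 4 stands ortho to a fused ring and that of compound 2 does not. Set side by side, the two steps cannot be told apart, so no dependence on the core can be read for this change: the same change on two cores in this assay, a number 9 percentage points lower (within the scatter) from compound 1 to compound 2 and a number 2 percentage points lower (within the scatter) from compound 3 to compound 4, 7 percentage points apart, within the scatter of two such steps

Among the compounds shown, only hydrogen and methyl stand on this ring, so it remains open whether any other group there gives a step that separates from the scatter at this one dose. An amine, a carboxylic acid or a longer chain on the same aromatic carbon would test this, and the same group placed on both cores would show whether such a step carries from one core to the other.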